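The compounds below may be only part of what the source reports. "The series", "measured", "known", "first", "only" and "open" are said of these compounds alone.

Series notes, compound 1 as the reference point. Going by the values given here, compound 1 `N/C(=N\NC(=S)N1CCOCC1)c1ccccn1` gives 15% in a functional assay on A-375 cells (Homo sapiens) for cytotoxicity, read by MTT assay, with a stated time of 72 h, tested at 30 uM (a lower number here means less inhibition of growth, a higher number more inhibition of growth at the concentration tested), and stands lowest of the two numbers so far; the nearest is compound 2 `Cc1ccnc(/C(N)=N/NC(=S)N2CCOCC2)c1`, which in this assay gives 87.4%. Among the compounds with values here, the one step recorded, a number 72.4 percentage points higher from compound 1 to compound 2 (beyond the scatter), is a methyl in place of hydrogen on an aromatic carbon of the shared core and is large.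

Compound 3 `Cc1cccc(/C(N)=N/NC(=S)N2CCOCC2)n1` is the next candidate; it differs from compound 1 by methyl in place of hydrogen on an aromatic carbon. Within the data shown here, only the step from compound 1 to compound 2 bears on this change, and it was large and upward; the methyl of compound 3 sits at a different aromatic carbon, so the transfer is uncertain. A rise in this assay beyond the scatter is nevertheless expected for compound 3, estimated as a number 40 percentage points higher from compound 1 to compound 3 (beyond the scatter), with a broad range. Compound 3 is therefore estimated at 55% in this assay, expected between 15% and 92%.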

Compound 3, percent growth inhibition at one concentration: 74.3%
The estimate for compound 3 lay 19.3 percentage points below the measured number; low and high end bracket the measured number.
By their numbers in this assay, from the lowest: compound 1; then compound 3; then compound 2.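

With the methyl on the aromatic carbon next to the ring nitrogen, this assay records a number 59.3 percentage points higher from compound 1 to compound 3 (beyond the scatter), so the large rise does not belong to the methyl position of compound 2 alone. Methyl in place of hydrogen has now been read at two different aromatic carbons of the shared core, and the other reading, a number 72.4 percentage points higher from compound 1 to compound 2 (beyond the scatter), points the same way. Nothing shown here gives a measured reason for either rise.

Going by these compounds, whether a larger or different group at this aromatic carbon, such as an ethyl chain, a methoxy group or an amine, gives a similar rise remains open. Also open, on these data alone, is whether a methyl on the remaining aromatic carbons of the ring would follow the same direction.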